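This account rests on a few compounds, and the source may have more. Where it says the series, first, only, none or still open, it means among the compounds named here.

Compound 1 `Clc1ccc(NCc2cncn2Cc2ccc(-c3ccccc3)cc2)cc1-c1ccccc1` was examined in a toxicity assay on NIH3T3 cells (Mus musculus) for cytotoxicity, read by resazurin assay; a lower number here means that less compound is needed, a higher number that more compound is needed for the effect. For compound 1 the this assay reading is only a limit, > 1000 nM. Compound 2 `CC(C)c1ccc(Cn2cncc2CNc2ccc(-c3nc4ccccc4s3)c(-c3ccccc3)c2)cc1` likewise returns only a limit in this assay, namely > 1000 nM. Compound 3 `COC(=O)c1ccc(NCc2cncn2Cc2ccc(Br)cc2)cc1-c1ccccc1` returns a limit of > 10000 nM in this assay. The three readings thus rest on two limits, the limit of > 1000 nM in this assay, at which 2 of the 3 values shown sit, and (the limit of > 10000 nM in this assay, at which 1 of the 3 values shown sits), and compound 1 shares the first of them. Compound 4 `COc1ccc(NCc2cncn2Cc2ccc(-c3ccccc3)cc2)cc1-c1ccccc1` differs from compound 1 by one change, (methoxy in place of chloro on an aromatic carbon). Within the data shown here, no measured pair shows this change, so the step in this assay is expected to be a step that the limit leaves unreadable from compound 1 to compound 4, none beyond the usual scatter. Compound 4 is therefore estimated at 3000 nM in this assay, within a range from 1000 nM to 10000 nM, and most probably as a limit once more.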

Compound 4, half-maximal effective concentration: > 1000 nM
Compound 4 gave a limit, no number (the forecaster's own chance of this, stated with the estimate: 75%); the middle value does not contradict the limit.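

Among these compounds, compound 1 and compound 4 both return only limits in this assay, so no step between them can be read: the limit of > 1000 nM in this assay, at which 3 of the 4 values shown sit. The compounds shown leave open whether methoxy in place of chloro on an aromatic carbon changes the concentration needed for the effect.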